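This account rests on a few compounds, and the source may have more. Where it says the series, first, only, none or still open, it means among the compounds named here.

Compound 3 `CC1=C(C(=O)NCCCN2CCC(c3ccccn3)CC2)[C@@H](c2ccc(F)c(F)c2)NC(=O)N1` carries a methyl on a double-bonded ring carbon of the shared core. In an assay on LM cells with Alpha-1B adrenergic receptor (Homo sapiens) as the target (on this read-out higher numbers stand for weaker inhibition and lower numbers for stronger inhibition), compound 3 reaches only the limit > 2000 nM, a boundary of the assay rather than a number. Compound 2 `O=C1NC=C(C(=O)NCCCN2CCC(c3ccccn3)CC2)[C@@H](c2ccc(F)c(F)c2)N1` differs from it by a hydrogen at that same ring carbon, and in this assay compound 2 gives 1850 nM. The step of an at least 1.0-fold higher number from compound 2 to compound 3 (0.03 log units; that floor lies within the scatter) rests on the limit of > 2000 nM in this assay, at which 1 of the 3 values shown sits, and gives no true size. For the measured compounds named here, compound 1 `COCC1=C(C(=O)NCCCN2CCC(c3ccc(F)cc3)CC2)[C@@H](c2ccc(F)c(F)c2)NC(=O)N1` carries the methoxymethyl but differs from compound 3 in another part of the molecule as well, so no single step connects them; in this assay compound 1 gives 41 nM.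

Compound 4 `COCC1=C(C(=O)NCCCN2CCC(c3ccccn3)CC2)[C@@H](c2ccc(F)c(F)c2)NC(=O)N1` has not yet been measured. Its change from compound 3 is methoxy in place of hydrogen on a saturated chain carbon bound to a double-bonded ring carbon. Going by the values given here, only the step from compound 2 to compound 3 touches this ring carbon, and it is a floor within the scatter; no measured step isolates the entering methoxy. Compound 1 shows that the methoxymethyl sits in a compound with a strong number, yet its other change is unaccounted for. Compound 4 is therefore expected to give about 800 nM in this assay, with a likely range from 150 nM to 4000 nM. That estimate for compound 4 would mean an expected step of an at least 2.5-fold lower number from compound 3 to compound 4 (0.39 log units; beyond the scatter), though the limit on compound 3 leaves its true size open.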

Compound 4, inhibition constant: 235 nM
Estimate against measurement, compound 4: 3.4-fold (0.53 log units) above, and the stated range covers the measured number.
By their numbers in this assay, from the lowest: compound 1; then compound 4; then compound 2. At a limit, above all of these: compound 3.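

The entering methoxy now has a step of its own in this assay, an at least 8.5-fold lower number from compound 3 to compound 4 (0.92 log units; beyond the scatter), and that step is only a floor, as compound 3 stands at a limit of the assay: the limit of > 2000 nM in this assay, at which 1 of the 4 values shown sits.

Measured against the hydrogen at the same double-bonded ring carbon, the methoxymethyl gives a step that rests on two numbers, a 7.9-fold lower number from compound 2 to compound 4 (0.90 log units; beyond the scatter), so the stronger binding read-out of the methoxymethyl compound does not depend on the limit alone. With the methoxymethyl held in place, the step of a 5.7-fold higher number from compound 1 to compound 4 (0.76 log units; beyond the scatter) shows that pyridin-2-yl in place of 4-fluorophenyl on a saturated ring carbon also moves the number beyond the scatter, so the methoxymethyl alone does not account for the strong value of the earlier compound.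

From the compounds shown here alone, the true size of the step from methyl to methoxymethyl stays open, as does whether that step would hold with 4-fluorophenyl in place of pyridin-2-yl. The compounds shown also do not tell whether a hydroxymethyl, an ethoxymethyl or an aminomethyl at that ring carbon would move the number in the same way.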